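Bromo for phenoxy on the seven-membered ring of an oxalamate

The compounds below may be only part of what the source reports. "The series", "measured", "known", "first", "only" and "open" are said of these compounds alone.

Measured so far:
Compound 1, `CCOC(=O)C(=O)Nc1c(Oc2ccccc2)ccccc1=O`, gives 0% in a functional assay on the whole organism (strain Sprague-Dawley CD) for inhibition, with Rattus norvegicus as the target, read by paw edema, at a dose of 30 mg/kg by the intraperitoneal route; a higher number here means a stronger effect of the compound at the dose given, a lower number a weaker effect.
Compound 2, `CCOC(=O)C(=O)Nc1ccccc(Oc2ccccc2)c1=O`, gives 16% in this assay.

Of the compounds shown here, two have been measured, and in this assay compound 2 gives 16%, the higher of the two numbers. Compound 1 gives 0% in this assay, a lower number, a gap that lies beyond the usual scatter of such measurements. Among the measured compounds shown here, no step between these two compounds is described here, so only their two numbers speak.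

The next compound, compound 3, `CCOC(=O)C(=O)Nc1ccccc(Br)c1=O`, carries one change against compound 2: bromo in place of phenoxy on an aromatic carbon. Whether so small a group in place of the phenoxy will keep the modest effect of compound 2 is the open question. Since compound 2 itself gives only 16% in this assay, there is little room for a fall, and nothing measured points to a rise. The step of a number 6 percentage points lower from compound 2 to compound 3 (within the scatter) is expected to stay within the scatter, if anything slightly downward. Compound 3 is therefore estimated at 10%, with a range from 0% to 28%.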

Compound 3, a percentage reported as inhibition, in the whole organism at one dose (the size of the read-out at that dose, not a potency): 52%
The estimate for compound 3 lay 42 percentage points below the measured number; the whole stated range lies below it.
By their numbers in this assay, from the lowest: compound 1; then compound 2; then compound 3.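

In this assay, the exchange of phenoxy for bromo on an aromatic carbon of the seven-membered aromatic ring, two ring bonds from the ring atom that bears a group of 8 heavy atoms, gives a number 36 percentage points higher from compound 2 to compound 3 (beyond the scatter). This shows that the phenoxy, with its six-membered aromatic ring, is not required at this place for the effect at this dose, and that a single bromine atom there goes with a clearly larger effect, something the first two compounds could not show. Nothing at hand bears on why this change raises the number.

What remains open is whether the gain belongs to bromo itself or simply follows from the loss of phenoxy, since a plain hydrogen, chloro, methoxy or an amine on this carbon does not stand among the compounds shown. Also open, from the compounds shown here alone, is how far the effect of compound 3 depends on the ethyl ester, which a carboxylic acid could replace, and how the effect would change at other doses.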